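The compounds below may be only part of what the source reports. "The series", "measured", "known", "first", "only" and "open" are said of these compounds alone.

Measured compounds in hand:

compound 1 `COc1ccc(CCCN2CCC(COC(c3ccc(Cl)cc3)c3ccc(Cl)cc3)CC2)cc1` — 1100 nM
compound 2 `COc1ccc(CCCN2CCC(C(O)CC(c3ccccc3)c3ccccc3)CC2)cc1` — 1500 nM
compound 3 `Clc1ccc(CCCN2CCC(COC(c3ccccc3)c3ccccc3)CC2)cc1` — 500 nM

In a functional assay on cells (T-cell line, Homo sapiens) for inhibition (a lower number here means a stronger inhibitor, a higher number a weaker inhibitor), compound 3 stands lowest of the three. Compound 1 in this assay is its nearest neighbour and compound 2 its furthest, and both gaps lie beyond the usual scatter, so compound 3 is the strongest inhibitor among the measured set. Among the measured compounds shown here, no pair of these three differs in a single place, so no measured step is available to guide the next compound.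

Compound 4 `CCCCCCCCCCN1CCC(COC(c2ccccc2)c2ccccc2)CC1` has not yet been measured in this assay. Against compound 3 the counted difference is heptyl in place of 4-chlorophenyl on a saturated chain carbon, three bonds along the chain from an amine nitrogen in a ring. The measured set holds no comparison of an aromatic ring against an open chain in this region, so the size and direction of the step are uncertain. A modest weakening in this assay is expected for compound 4, with the result for compound 4 estimated at 900 nM and a range from 300 nM to 2700 nM. The expected step is a 1.8-fold higher number from compound 3 to compound 4 (0.26 log units; within the scatter).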

Compound 4, half-maximal inhibitory concentration: 2600 nM
Compound 4: middle estimate off by 2.9-fold (0.46 log units), on the low side; low and high end bracket the measured number.
By their numbers in this assay, from the lowest: compound 3; then compounds 1, 2 and 4 (each within the scatter of the next, the first and the last beyond it).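

In this assay, among the compounds shown here, heptyl in place of 4-chlorophenyl gives a 5.2-fold higher number from compound 3 to compound 4 (0.72 log units; beyond the scatter), the first step that can be read across a single change. Both groups count the same number of heavy atoms and neither carries a hydrogen-bond donor or acceptor, so the counted difference is an aromatic ring with its chlorine against an open chain, and the ring-bearing compound 3 has the lower number. Nothing in hand accounts for the size of this step.

Open, on these data alone, is whether the ring or its chlorine carries the difference: an unsubstituted 3-phenylpropyl group and a 3-cyclohexylpropyl group would separate the two. Also open, as far as these compounds go, is how the open chain depends on length, with a hexyl group as the shorter comparison to decyl.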